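This account rests on a few compounds, and the source may have more. Where it says the series, first, only, none or still open, it means among the compounds named here.

Measured compounds and their values in a functional assay, with stated times of 30 s and 6 min, in the presence of a further agent that is not named here; on this read-out higher numbers stand for weaker inhibition and lower numbers for stronger inhibition:

compound 1, `CCCCOc1cc(OC)c(Br)cc1C(C)=O`: 38200000 nM
compound 2, `CCCCCCOc1cc(OC)c(Br)cc1C(C)=O`: 34000000 nM
compound 3, `CCCCCCCCCCCCCCOc1cc(OC)c(Br)cc1C(C)=O`: 6800000 nM

Compound 1 and compound 2 differ by ethyl in place of hydrogen on a saturated chain carbon, four bonds along the chain from an oxygen on an aromatic ring. That change gave a 1.1-fold lower number from compound 1 to compound 2 (0.05 log units; within the scatter). Going on from compound 2 to compound 3, a longer chain enters, and this gave a 5.0-fold lower number from compound 2 to compound 3 (0.70 log units; beyond the scatter). The difference between the core of compound 1 and the core of compound 3 is not broken down here.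

Compound 4, `CCCCCCCCCCCCCCCCOc1cc(OC)c(Br)cc1C(C)=O`, has not yet been measured in this assay. It differs from compound 3 by ethyl in place of hydrogen on a saturated chain carbon, ten or more bonds along the chain from an oxygen on an aromatic ring. This is the same kind of change as that from compound 1 to compound 2, but at a different place on the chain. Since the earlier ethyl step gave only a 1.1-fold lower number from compound 1 to compound 2 (0.05 log units; within the scatter), a small step is expected here too, and the number estimated for compound 4 is 5000000 nM, between 2000000 nM and 12000000 nM, which means an expected step of a 1.4-fold lower number from compound 3 to compound 4 (0.13 log units; within the scatter).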

Compound 4, half-maximal inhibitory concentration: 1800000 nM
Compound 4: middle estimate off by 2.8-fold (0.44 log units), on the high side; measured number below the stated range.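

In this assay, ethyl in place of hydrogen on a saturated chain carbon, ten or more bonds along the chain from an oxygen on an aromatic ring, gave a 3.8-fold lower number from compound 3 to compound 4 (0.58 log units; beyond the scatter). Set beside the same change made four bonds along the chain, the step did not carry over at one size from one core to the other: the same change on two cores in this assay, a 1.1-fold lower number (0.05 log units; within the scatter) from compound 1 to compound 2 and a 3.8-fold lower number (0.58 log units; beyond the scatter) from compound 3 to compound 4, 3.4-fold (0.53 log units) apart, beyond the scatter of two such steps. This shows that the size of the ethyl step in this series cannot be taken from one core and applied to another, but two steps alone do not show how the step varies with chain length or why the two differ.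

The compounds shown leave open whether a longer chain would lower the number further or whether the steps would level off. They also leave open how a chain ending in an amine or a carboxylic acid would compare with these plain chains, and whether the ethyl step would hold on a core carrying chlorine in place of bromine.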